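This account rests on a few compounds, and the source may have more. Where it says the series, first, only, none or still open, it means among the compounds named here.

Compound 1 `Cc1nccn1-c1ccc(COc2cc(F)cc(C3(C(N)=O)CCOCC3)c2)cc1` is the starting point of this comparison. In an assay on blood for inhibition of Polyunsaturated fatty acid 5-lipoxygenase (Homo sapiens) (a higher number here means a weaker inhibitor, a lower number a stronger inhibitor), compound 1 gives 340 nM, the highest of the two numbers on hand, with compound 2 as its nearest neighbour. Compound 2 `CCOC1(c2cc(F)cc(OCc3ccc(-n4ccnc4C)cc3)c2)CCOCC1` gives 80 nM in this assay, so the step of a 4.3-fold lower number from compound 1 to compound 2 (0.63 log units; beyond the scatter) is a modest gain. Compound 3 `Cc1nccn1-c1ccc(COc2cc(F)cc(C3(S(C)(=O)=O)CCOCC3)c2)cc1` is reported only as a limit, > 1000 nM, which is the limit of > 1000 nM in this assay, at which 1 of the 3 values shown sits. That limit makes the step of an at least 2.9-fold higher number from compound 1 to compound 3 (0.46 log units; beyond the scatter) and the step of an at least 12-fold higher number from compound 2 to compound 3 (1.09 log units; beyond the scatter) a loss in each case.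

Compound 4 `Cc1nccn1-c1ccc(COc2cc(F)cc(C3(C(=O)N(C)C)CCOCC3)c2)cc1` has not yet been measured in this assay. It differs from compound 1 in one place: dimethylamino in place of amino on a carbonyl carbon. Both earlier steps from compound 1 replaced the carbamoyl group itself, one with ethoxy and one with methylsulfonyl, and they ran in opposite directions; neither swaps only the amino for dimethylamino, so they give only a loose guide. Compound 4 is therefore expected to stay close to compound 1, with a step of about a 1.1-fold lower number from compound 1 to compound 4 (0.05 log units; within the scatter) in this assay. Compound 4 is estimated at 300 nM, most likely between 100 nM and 1000 nM.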

Compound 4, half-maximal inhibitory concentration: 810 nM
Compound 4: middle estimate off by 2.7-fold (0.43 log units), on the low side, within the range that was stated.
By their numbers in this assay, from the lowest: compound 2; then compound 1; then compound 4. At a limit, above all of these: compound 3.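

Compound 4 keeps the carbonyl of compound 1 and changes only the group on it, and in this assay that change gives a 2.4-fold higher number from compound 1 to compound 4 (0.38 log units; beyond the scatter) as a modest step towards a weaker inhibitor. Replacing amino with dimethylamino therefore does not help here, and the whole group on the saturated ring carbon still matters: ethoxy, at that same carbon, compares with dimethylcarbamoyl as a 10-fold higher number from compound 2 to compound 4 (1.01 log units; beyond the scatter) in a large step. The remaining step reads an at least 1.2-fold lower number from compound 3 to compound 4 (0.09 log units; that floor lies within the scatter) and its floor lies within the scatter, so these two compounds cannot be placed in order. Compound 3 is known only as a limit: the limit of > 1000 nM in this assay, at which 1 of the 4 values shown sits.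

The data do not explain why the number rises, and they cannot tell whether one methyl on the amide nitrogen would already produce the change or whether both are needed; methylamino on the same carbonyl carbon would separate these two cases. Going by these compounds, it also remains open whether other groups on the saturated ring carbon, such as a methoxy, a longer ether chain or a hydroxyl, would match or improve on the ethoxy of compound 2.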